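From Butyl to Cyclopentylmethyl: An Estimate for Compound 4

The source may report more compounds than this note shows. Statements on the series, on what has been measured and on what is new or still open speak of the compounds shown alone.

Compound 1, `CNc1nc(-n2cc(-c3ccccn3)nn2)nc2c1ncn2[C@@H]1O[C@H](CO)[C@@H](O)[C@H]1O`, gives 10.3 nM in an assay on CHO cells for displacement of a labelled ligand from adenosine receptor A3 (Homo sapiens); a lower number here means a stronger inhibitor, a higher number a weaker inhibitor.
Compound 2, `CCCCc1cn(-c2nc(NC)c3ncn([C@@H]4O[C@H](C(=O)NCC)[C@@H](O)[C@H]4O)c3n2)nn1`, gives 5.6 nM in this assay.
Compound 3, `CCCCc1cn(-c2nc(NC)c3ncn([C@@H]4O[C@H](CO)[C@@H](O)[C@H]4O)c3n2)nn1`, gives 11.7 nM in this assay.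

Compound 3 has the highest number of the three, but it stands close to compound 1: the step of a 1.1-fold higher number from compound 1 to compound 3 (0.06 log units; within the scatter) lies within the scatter. The step of a 2.1-fold higher number from compound 2 to compound 3 (0.32 log units; beyond the scatter) is modest and beyond the scatter, and it concerns a change on the saturated ring rather than on the aromatic substituent.

Compound 4, `CNc1nc(-n2cc(CC3CCCC3)nn2)nc2c1ncn2[C@@H]1O[C@H](CO)[C@@H](O)[C@H]1O`, differs from compound 3 by cyclopentyl in place of propyl on a saturated chain carbon bound to an aromatic carbon. The step that bears on this change is a 1.1-fold higher number from compound 1 to compound 3 (0.06 log units; within the scatter), where a different group on the same aromatic carbon left the number essentially unchanged. Among the measured compounds shown here, no measured step reports a change on a saturated chain carbon, so the expectation rests on that single comparison. Compound 4 is therefore expected to show no step beyond the scatter, a 1.2-fold lower number from compound 3 to compound 4 (0.07 log units; within the scatter). The estimate for compound 4 in this assay is 10 nM, with a range from 4 nM to 30 nM.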

Compound 4, inhibition constant: 1.3 nM
Estimate against measurement, compound 4: 7.7-fold (0.89 log units) above, outside the stated range (below it).
By their numbers in this assay, from the lowest: compound 4; then compounds 2, 1 and 3 (each within the scatter of the next, the first and the last beyond it).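

The group on this aromatic carbon does matter in this assay. Butyl and pyridin-2-yl had given numbers within the scatter of each other, which made the position look indifferent to the group it carries, yet cyclopentylmethyl in place of butyl gives a clear drop (  a 9.0-fold lower number from compound 3 to compound 4 (0.95 log units; beyond the scatter)) and cyclopentylmethyl in place of pyridin-2-yl gives one of similar size (a 7.9-fold lower number from compound 1 to compound 4 (0.90 log units; beyond the scatter)). The change adds a five-membered non-aromatic ring of carbon only and no hydrogen-bond donor or acceptor, and no measurement shown here accounts for its effect on the number.

The compounds shown leave open whether the gain needs the ring itself or only the added carbon, which a straight hexyl chain could test. They also leave open whether the ring size matters, as cyclohexylmethyl on the same carbon would show.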